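Swapping the benzyl halogen in a chalcone-triazole pair

The source may hold more compounds than are shown below. What is called first, only, known or untested is meant among the compounds shown, and "the series" means these compounds.

Compound 2 `COc1ccc(C(=O)/C=C/c2ccc(OCc3cn(Cc4cccc(Br)c4)nn3)cc2)cc1` and compound 1 `O=C(/C=C/c1ccc(OCc2cn(Cc3ccccc3F)nn2)cc1)c1ccc(Br)cc1` have both been tested in a functional assay on MCF7 cells (Homo sapiens) for inhibition, read by MTT assay, with a stated time of 48 h, tested at 10 uM; a lower number here means less inhibition of growth, a higher number more inhibition of growth at the concentration tested. Compound 2 gives 45% and compound 1 gives 38%; these two numbers lie within the usual scatter of each other, so neither can be set above the other. Compound 3 `COc1ccc(C(=O)/C=C/c2ccc(OCc3cn(Cc4ccccc4F)nn3)cc2)cc1` is not yet measured. It differs from compound 2 by 2-fluorophenyl in place of 3-bromophenyl on a saturated chain carbon bound to an aromatic nitrogen. Within the data shown here, no single step of this kind has been measured here, so a change no larger than the scatter is expected, in either direction. Compound 3 is estimated at 41% with a range from 26% to 56%, which means an expected step of a number 4 percentage points lower from compound 2 to compound 3 (within the scatter).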

Compound 3, percent growth inhibition at one concentration: 32%
Compound 3: middle estimate off by 9 percentage points, on the high side, within the range that was stated.
By their numbers in this assay, from the lowest: compounds 3, 1 and 2 (each within the scatter of the next, the first and the last beyond it).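

In this assay, among these compounds, the group on this saturated chain carbon now makes a readable difference: 2-fluorophenyl in place of 3-bromophenyl gives a number 13 percentage points lower from compound 2 to compound 3 (beyond the scatter) and is the first step here to clear the scatter. Methoxy in place of bromo on an aromatic carbon gives a number 6 percentage points lower from compound 1 to compound 3 (within the scatter) and so shows no readable effect. No measurement on hand explains either step. The halogen and its place on the ring change together, so the compounds shown cannot separate the two. On these data alone, how an unsubstituted phenyl or a phenyl carrying an amine would read at this position also stays open.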